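Aryl-oxadiazole series: anilino replacement at the oxadiazole carbon

A few compounds are considered here, and "the series" means these few. Any claim that something is new, unique, unknown or untested is made for them only; others in the source may bear on it.

Three compounds sharing one core have numbers in an assay on tissue (HeLa cells) for inhibition of Indoleamine 2,3-dioxygenase 1 (Homo sapiens), read by fluorescence, with a stated time of 18 h; on this read-out lower numbers stand for stronger inhibition and higher numbers for weaker inhibition. Compound 1 `C[C@@H](c1nnc(-c2ccc(Cl)cc2)o1)[C@H]1CC[C@@H](c2ccnc3ccc(F)cc32)CC1` gives 239 nM, the second highest of the three. Compound 2 `C[C@@H](c1ncc(-c2ccc(Cl)cc2)o1)[C@H]1CC[C@@H](c2ccnc3ccc(F)cc32)CC1` gives 495 nM, a higher number than compound 1 and beyond the usual scatter. Compound 3 `C[C@@H](c1nc2cc(F)ccc2[nH]1)[C@H]1CC[C@@H](c2ccnc3ccc(F)cc32)CC1` gives 3 nM, far below compound 1 and by a wide margin the lowest number in the set. For the measured compounds named here, no single-point comparisons between the measured compounds are available, so the spread between compound 1 and compound 3 shows only that this core tolerates very different five-membered ring substituents with very different outcomes.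

Compound 4 `COc1ccc(Nc2nnc([C@H](C)[C@H]3CC[C@@H](c4ccnc5ccc(F)cc54)CC3)o2)cc1` has not yet been measured. It differs from compound 1 in one place: (4-methoxyphenyl)amino in place of 4-chlorophenyl on an aromatic carbon. The entering group brings 1 hydrogen-bond donor and 2 hydrogen-bond acceptors where the leaving 4-chlorophenyl had none. Going by the values given here, the data give no precedent for this change on the oxadiazole, so the expected step is modest: a small move toward a lower number in this assay, close to the usual scatter, is estimated for a 1.6-fold lower number from compound 1 to compound 4 (0.20 log units; within the scatter). On that basis compound 4 is expected to give about 150 nM in this assay, within a range of 30 nM to 800 nM.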

Compound 4, half-maximal inhibitory concentration: 165 nM
Compound 4: the middle estimate sits 1.1-fold (0.04 log units) below what was measured; the range from low to high includes it.
By their numbers in this assay, from the lowest: compound 3; then compounds 4 and 1 (each within the scatter of the next); then compound 2.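

In this assay, replacing 4-chlorophenyl with (4-methoxyphenyl)amino on the aromatic carbon of the five-membered aromatic ring with 2 nitrogen and 1 oxygen gives a 1.4-fold lower number from compound 1 to compound 4 (0.16 log units; within the scatter), so this read-out does not separate the two compounds. For the compounds shown here, this is the first single-place comparison, and it shows that this position accepts the larger entering group, with its 1 hydrogen-bond donor and 2 hydrogen-bond acceptors, without a step beyond the usual scatter. No measured evidence bears on why the two numbers stay so close, and the step alone gives no explanation.

Because the amino link and the methoxy enter together, their separate contributions remain unresolved, and a (4-chlorophenyl)amino or plain phenylamino group on the same carbon would be needed to tell them apart. On these data alone, it also remains open whether an amine or a carboxylic acid on the phenyl ring of compound 4 would move the number beyond the scatter in this assay, or whether this position stays as flat for such groups.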